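Series notes: amide nitrogen substituent in aryloxyacetamides

A few compounds are considered here, and "the series" means these few. Any claim that something is new, unique, unknown or untested is made for them only; others in the source may bear on it.

Measured so far:
- compound 1, `CCN(C(=O)COc1ccc(C)cc1)C(C)c1cccs1`, an assay on HEK293 cells for agonist activity at transient receptor potential cation channel subfamily M member 8 (Homo sapiens), read by fluorescence and calcium flux, with a stated time of 15 min; a higher number here means that more compound is needed for the effect, a lower number that less compound is needed: "not active" (no number reported)
- compound 2, `Cc1ccc(OCC(=O)N(Cc2cccs2)c2ccccn2)cc1`: 200 nM
- compound 3, `Cc1ccc2oc(C(=O)N(Cc3cccs3)c3ccn[nH]3)cc2c1`: 40 nM

Compound 2 holds the highest of the two numbers reported in this assay. For the measured compounds named here, the nearest neighbour is compound 3, which differs in both the acyl part and the group on the amide-type nitrogen, and whose number lies beyond the scatter on the lower side; no single step between them is computed here, so only the two values themselves are compared. Compound 1 returns no number.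

Compound 4, `Cc1ccc(OCC(=O)N(Cc2cccs2)c2ccn[nH]2)cc1`, keeps the acyl part of compound 2 and changes only the amide-type nitrogen substituent: 1H-pyrazol-5-yl in place of pyridin-2-yl on an amide-type nitrogen. Going by the values given here, the group that enters is the one carried by compound 3, whose value of 40 nM is the lower of the two numbers. On that basis a step toward a lower number is expected for compound 4, a 2.0-fold lower number from compound 2 to compound 4 (0.30 log units; within the scatter), though the acyl part also differs between compound 2 and compound 3, so the size is uncertain. Compound 4 is expected to give 100 nM, with a range from 30 nM to 400 nM.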

Compound 4, half-maximal effective concentration: 0.2 nM
For compound 4 the middle estimate is 500-fold (2.70 log units) above the measured one, outside the stated range (below it).
By their numbers in this assay, from the lowest: compound 4; then compound 3; then compound 2.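

At the amide-type nitrogen whose other neighbours are a carbonyl carbon and a saturated chain carbon, the substituent has a large effect in this assay: with the acyl part held constant, 1H-pyrazol-5-yl in place of pyridin-2-yl gives a 1000-fold lower number from compound 2 to compound 4 (3.00 log units; beyond the scatter) and so separates this position from the acyl part, which compound 3 could not do. The change replaces a six-membered aromatic ring with a five-membered one and adds a hydrogen-bond donor. No measurement available here indicates which of these differences accounts for the step.

The compounds shown leave open how 1-methyl-1H-pyrazol-5-yl or phenyl on the same nitrogen would read. They also leave open whether pyridin-2-yl in place of 1H-pyrazol-5-yl gives a step of similar size with the acyl part of compound 3.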